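The source may hold more compounds than are shown below. What is called first, only, known or untested is meant among the compounds shown, and "the series" means these compounds.

Compound 1 `COc1ccc(NC(=O)[C@H]2CCCN2C(=O)C2(c3cccc(Cl)c3)CCCC2)nc1` and compound 2 `O=C(Nc1ccc2[nH]ncc2n1)[C@H]1CCCN1C(=O)C1(c2ccc(F)cc2)CCC1` share a core; they differ in the group on the amide nitrogen and in the ring carrying the halogenated phenyl. In an assay on isolated protein for inhibition of histone acetyltransferase p300 (Homo sapiens), with a stated time of 60 min (on this read-out higher numbers stand for weaker inhibition and lower numbers for stronger inhibition), compound 1 gives 2 nM, the higher of the two numbers, while compound 2 gives 0.126 nM. Compound 3 `O=C(Nc1ccc2[nH]ncc2c1)[C@H]1CCCN1C(=O)C1(c2cccc(Cl)c2)CCCC1` takes the step (1H-indazol-5-yl in place of 5-methoxypyridin-2-yl on an amide-type nitrogen). For the measured compounds named here, no measured pair isolates this change. Because compound 2 reaches 0.126 nM with a related fused-ring amide, a step toward stronger inhibition is expected, a 3.3-fold lower number from compound 1 to compound 3 (0.52 log units; beyond the scatter). Compound 3 is therefore estimated at 0.6 nM, within 0.1 nM to 3 nM.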

Compound 3, half-maximal inhibitory concentration: 1 nM
Compound 3: the middle estimate sits 1.7-fold (0.22 log units) below what was measured; low and high end bracket the measured number.
By their numbers in this assay, from the lowest: compound 2; then compounds 3 and 1 (each within the scatter of the next).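

In this assay, placing 1H-indazol-5-yl instead of 5-methoxypyridin-2-yl on the amide-type nitrogen gives a 2.0-fold lower number from compound 1 to compound 3 (0.30 log units; within the scatter) and so does not separate the two groups. This position therefore takes either one six-membered aromatic ring or a six- and five-membered aromatic pair, which also brings in a hydrogen-bond donor, without a change that can be read. No measurement at hand explains this result. Going by these compounds, whether the same nitrogen also accepts a group with no aromatic ring, such as a cyclohexyl ring or a short alkyl chain, stays open.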